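The source may report more compounds than this note shows. Statements on the series, on what has been measured and on what is new or still open speak of the compounds shown alone.

Measured in a functional assay on HeLa cells (Homo sapiens) for inhibition, read by CCK-8 assay, with a stated time of 72 h, tested at 10 uM; a lower number here means less inhibition of growth, a higher number more inhibition of growth at the concentration tested:
- Compound 1 `CN(C)C(=O)c1cc2cnc(Nc3ccc(N)cn3)nc2n1C1CCCC1`: 68.7%
- Compound 2 `CN(C)C(=O)c1cc2cnc(Nc3ccc(NC(=O)C4(C(=O)Nc5cccc(O)c5)CC4)cc3)nc2n1C1CCCC1`: 96.6%
- Compound 3 `Nc1ccc(NC(=O)C2(C(=O)Nc3ccc(F)cc3)CC2)cc1F`: 71.8%

Among these three, compound 2 stands highest at 96.6%. Compound 3 at 71.8% and compound 1 at 68.7% both lie below it by more than the usual scatter of repeat measurements, while those two lie within the scatter of each other.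

The next compound to be tested is compound 4 `CN(C)C(=O)c1cc2cnc(Nc3ccc(NC(=O)C4(C(=O)Nc5ccc(O)cc5)CC4)cc3)nc2n1C1CCCC1`. It has the same atoms as compound 2, joined differently: 4-hydroxyphenyl in place of 3-hydroxyphenyl on an amide-type nitrogen. In words, 4-hydroxyphenyl stands in place of 3-hydroxyphenyl on an amide-type nitrogen, and the rest of the molecule stays the same.

Going by the values given here, no two measured compounds differ in only one place, so the data do not show directly what a swap like this does. The prediction therefore rests on how closely compound 4 resembles compound 2 and on how little room remains on this scale, because compound 2 already reaches 96.6%. The expected step of a number 4.6 percentage points lower from compound 2 to compound 4 (within the scatter) is small, slightly downward and within the scatter. For compound 4 the estimated value is 92%, with an expected range of 78% to 100%.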

Compound 4, percent growth inhibition at one concentration: 99.9%
Compound 4: the middle estimate sits 7.9 percentage points below what was measured; the range from low to high includes it.
By their numbers in this assay, from the lowest: compounds 1 and 3 (each within the scatter of the next); then compounds 2 and 4 (each within the scatter of the next).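

Placing 4-hydroxyphenyl in place of 3-hydroxyphenyl on the amide-type nitrogen is the first change here that can be read in one place, and in this assay it gives a number 3.3 percentage points higher from compound 2 to compound 4 (within the scatter), so this read-out cannot tell the two forms apart. Compound 2 gives 96.6% and compound 4 gives 99.9%, both close to the top of the scale, where a test at a single concentration leaves little room to separate compounds. Nothing available explains why the two forms give such similar values.

From the compounds shown here alone, it remains open whether the hydroxyl group itself matters on this nitrogen, which a plain phenyl, a 4-methoxyphenyl or a 4-aminophenyl group in the same place would help to show. Going by these compounds, it is also open whether compound 2 and compound 4 would still look alike at lower concentrations, where values away from the top of the scale could reveal a difference that stays hidden here.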